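This account rests on a few compounds, and the source may have more. Where it says the series, first, only, none or still open, it means among the compounds named here.

Compound 3 `Cc1ccc2ncc(S(=O)(=O)c3ccc(C)c(Cl)c3)c(N3CCC(C)CC3)c2c1` is the compound this account starts from. In an assay on isolated protein for displacement of a labelled ligand from metabotropic glutamate receptor 5 (Homo sapiens), with a stated time of 60 min, tested at 1 uM (on this read-out lower numbers stand for less inhibition and higher numbers for more inhibition at the one concentration tested (going by the name of the read-out)), compound 3 gives 91%, the highest of the three numbers measured, yet the other two compounds lie within the usual scatter of it: compound 1 `Cc1ccc2ncc(S(=O)(=O)c3ccc(F)cc3)c(N3CCC(C)CC3)c2c1` gives 90% and the step of a number 1 percentage points higher from compound 1 to compound 3 (within the scatter) is small, while compound 2 `Cc1ccc2ncc(S(=O)(=O)c3ccc(Cl)c(Cl)c3)c(N3CCC(C)CC3)c2c1` gives 82% and the step of a number 9 percentage points higher from compound 2 to compound 3 (within the scatter) is likewise within the scatter. The change from compound 3 to compound 4 `Cc1ccc(S(=O)(=O)c2cnc3ccc(C)cc3c2N2CCC(C)CC2)cc1` is hydrogen in place of chloro on an aromatic carbon. Among the compounds with values here, two measured steps bear on it, both changes on the same sulfonyl-bound phenyl: the step of a number 8 percentage points lower from compound 1 to compound 2 (within the scatter) and the step of a number 9 percentage points higher from compound 2 to compound 3 (within the scatter), each within the scatter. Within the data shown here, no measured step removes a chloro for a hydrogen, so the closest evidence is that exchanges of substituents on this ring have barely moved this assay. The expectation for compound 4 is therefore a step of a number 5 percentage points lower from compound 3 to compound 4 (within the scatter), no larger than the scatter. Compound 4 is estimated at 86%, in the range from 74% to 95%.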

Compound 4, a percentage reported as inhibition, at one concentration (the size of the read-out at that concentration, not a potency): 82%
The estimate for compound 4 lay 4 percentage points above the measured number; low and high end bracket the measured number.
By their numbers in this assay, from the lowest: compounds 2, 4, 1 and 3 (each within the scatter of the next).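

Within the data shown here, compound 4 gives the first measured exchange of chloro for hydrogen at this place, ortho to a methyl group, and in this assay the result is a number 9 percentage points lower from compound 3 to compound 4 (within the scatter) on the sulfonyl-bound phenyl. The other two comparisons with the 4-methylphenyl group read no change at the digits printed from compound 2 to compound 4 (within the scatter) and a number 8 percentage points lower from compound 1 to compound 4 (within the scatter), so a number of this size in this assay does not depend on the chloro at this place among these compounds. Nothing available here accounts for the size of these steps.

From the compounds shown here alone, how a carboxylic acid or a dimethylamino group at this place would read in this assay remains open. Going by these compounds, every number here also comes from a single concentration, so whether these four compounds differ in potency stays unknown.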